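The compounds below may be only part of what the source reports. "The series", "measured", "known", "first", "only" and "open" are said of these compounds alone.

Compound 1 `Cc1ccc(S(=O)(=O)/C(=C/c2ccc(O)c([N+](=O)[O-])c2)C(=O)c2ccc(Cl)cc2)cc1`: 25000 nM
Compound 2 `O=C(/C(=C\c1ccc(O)c([N+](=O)[O-])c1)S(=O)(=O)Cc1ccccc1Cl)c1ccc(Cl)cc1`: 10000 nM

In a functional assay on DU-145 cells (Homo sapiens) for inhibition, read by trypan blue exclusion, with a stated time of 96 h (on this read-out lower numbers stand for stronger inhibition of growth and higher numbers for weaker inhibition of growth), compound 2 holds the lower of the two numbers, at 10000 nM. Within the data shown here, the one measured step, a 2.5-fold lower number from compound 1 to compound 2 (0.40 log units; beyond the scatter), is modest and lies at the sulfonyl sulfur, where 2-chlorobenzyl stands in place of 4-methylphenyl.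

Compound 3 `COc1ccc(/C=C(\C(=O)c2ccc(Cl)cc2)S(=O)(=O)Cc2ccccc2Cl)cc1` keeps that 2-chlorobenzyl and differs from compound 2 elsewhere: 4-methoxyphenyl in place of 4-hydroxy-3-nitrophenyl on a double-bonded chain carbon bound to a double-bonded chain carbon. This puts 4-methoxyphenyl in place of 4-hydroxy-3-nitrophenyl on a double-bonded chain carbon bound to a double-bonded chain carbon. Among the measured compounds shown here, no measured step touches this place, so the data give no direction for the change. The step of a 2.5-fold lower number from compound 1 to compound 2 (0.40 log units; beyond the scatter) offers only a rough guide to size, since it was made at another place. In this assay, from the compounds shown here alone, the best expectation is therefore no step beyond the scatter, though a step of either direction remains open and the range must stay wide. The expected step is a 1.3-fold lower number from compound 2 to compound 3 (0.10 log units; within the scatter). The estimated value for compound 3 is 8000 nM, with an expected range of 2000 nM to 30000 nM.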

Compound 3, concentration for 50% growth inhibition: 50000 nM
Compound 3: the middle estimate sits 6.3-fold (0.80 log units) below what was measured; measured number outside the range, above it.
By their numbers in this assay, from the lowest: compound 2; then compounds 1 and 3 (each within the scatter of the next).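

The change from 4-hydroxy-3-nitrophenyl to 4-methoxyphenyl on a double-bonded chain carbon bound to a double-bonded chain carbon gives the first direction at this place in this assay (a 5.0-fold higher number from compound 2 to compound 3 (0.70 log units; beyond the scatter)). With the 2-chlorobenzyl on the sulfonyl sulfur kept, growth inhibition weakens when 4-methoxyphenyl enters, so the group at this place matters to the read-out and the earlier step at the sulfonyl sulfur could not have shown this. That earlier step (a 2.5-fold lower number from compound 1 to compound 2 (0.40 log units; beyond the scatter)) runs the opposite way, and both steps are modest and beyond the scatter; nothing available here accounts for the rise at this place.

The swap changes the hydroxyl, the nitro group and the methoxy group in a single move, so these compounds cannot say which of them carries the step, and a phenyl bearing only the hydroxyl or only the nitro group, or an amine in their stead, would be needed to separate them. From the compounds shown here alone, it also remains open whether the same change would move the number in the same direction with 4-methylphenyl on the sulfonyl sulfur.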